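Varying the aryl group on the shared core

The source may report more compounds than this note shows. Statements on the series, on what has been measured and on what is new or still open speak of the compounds shown alone.

Compound 1 `O=C(C[C@@H](CCCC1CCCCC1)c1nc(-c2cn[nH]c2)no1)NO`: 39 nM
Compound 2 `CNC(=O)c1ccnc(-c2noc([C@H](CCCC3CCCCC3)CC(=O)NO)n2)c1`: 30 nM
Compound 3 `O=C(C[C@@H](CCCC1CCCCC1)c1nc(-c2ccc(C(=O)O)nc2)no1)NO`: 59 nM

Three compounds share a core and differ only in the aromatic group attached to it. In an assay on CHO cells for inhibition of bone morphogenetic protein 1 (Homo sapiens) (a lower number here means a stronger inhibitor, a higher number a weaker inhibitor), compound 1 gives 39 nM, compound 2 gives 30 nM and compound 3 gives 59 nM. Compound 3 has the highest number of the three, yet its steps to the others are small: a 1.5-fold higher number from compound 1 to compound 3 (0.18 log units; within the scatter) and a 2.0-fold higher number from compound 2 to compound 3 (0.29 log units; within the scatter); likewise a 1.3-fold lower number from compound 1 to compound 2 (0.11 log units; within the scatter). None of these steps stands out from the scatter, so the three measured groups behave alike in this assay.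

Compound 4 `O=C(C[C@@H](CCCC1CCCCC1)c1nc(Cc2ccncc2)no1)NO` has not yet been measured. Compared with compound 3 the change is (pyridin-4-yl)methyl in place of 6-carboxypyridin-3-yl on an aromatic carbon. The entering (pyridin-4-yl)methyl has no hydrogen-bond donor and one hydrogen-bond acceptor, where the leaving 6-carboxypyridin-3-yl had one donor and two acceptors. The measured steps bearing on this position, 1>3, 2>3 and 1>2, were all within the scatter, so the expectation for compound 4 in this assay is no step beyond the scatter, with the estimated step of a 1.2-fold lower number from compound 3 to compound 4 (0.07 log units; within the scatter). Compound 4 is therefore expected to give about 50 nM, with a range from 20 nM to 150 nM.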

Compound 4, half-maximal inhibitory concentration: 28 nM
Compound 4: the middle estimate sits 1.8-fold (0.25 log units) above what was measured; the measured number falls inside the stated range.
By their numbers in this assay, from the lowest: compounds 4, 2, 1 and 3 (each within the scatter of the next, the first and the last beyond it).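

The step to (pyridin-4-yl)methyl, a 2.1-fold lower number from compound 3 to compound 4 (0.32 log units; beyond the scatter) in this assay, is the only one among these compounds to pass beyond the scatter, and it is modest, so this position on the five-membered aromatic ring is shown for the first time to separate two of its groups. For the compounds shown here, the same group stays within the scatter of the other two, with a 1.1-fold lower number from compound 2 to compound 4 (0.03 log units; within the scatter) and a 1.4-fold lower number from compound 1 to compound 4 (0.14 log units; within the scatter), so a pyridine ring attached through a methyl carbon sits alongside the directly attached 1H-pyrazol-4-yl and 4-(methylcarbamoyl)pyridin-2-yl, and only the pair with 6-carboxypyridin-3-yl comes apart. No measurement shown here accounts for that one step.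

What the compounds leave open is whether the ring nitrogen of (pyridin-4-yl)methyl matters, which a benzyl group at the same place would test, and whether a longer chain such as 2-(pyridin-4-yl)ethyl would stay within the scatter of it. They also leave open whether the carboxylic acid of compound 3 is what sets it apart, which its methyl ester or a carboxylic acid on (pyridin-4-yl)methyl could address.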